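Replacing 4-chlorobenzyl by phenyl on the amide nitrogen

The source may report more compounds than this note shows. Statements on the series, on what has been measured and on what is new or still open speak of the compounds shown alone.

Compound 1, `C=CC1=C(C(=O)NCCC)C(c2ccc(OC)c(OC)c2)OC1`: in a functional assay on SW480 cells (Homo sapiens) for cytotoxicity, read by MTT assay, with a stated time of 24 h (on this read-out lower numbers stand for stronger inhibition and higher numbers for weaker inhibition), compound 1 gives > 100000 nM, which is a limit of the assay and not a number.
Compound 2, `C=CC1=C(C(=O)NCc2ccc(Cl)cc2)C(c2ccc(OC)c(OC)c2)OC1`: in this assay compound 2 gives > 100000 nM, again a limit of the assay rather than a number.

Compound 2 therefore sits at the top edge of what this assay can report, and it does not stand alone there: the limit of > 100000 nM in this assay, at which 2 of the 2 values shown sit. The only measured step among these compounds is the one from compound 1 to compound 2, and it reads a step that the two limits leave unreadable from compound 1 to compound 2, so it gives no usable size or direction.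

The new compound is compound 3, `C=CC1=C(C(=O)Nc2ccccc2)C(c2ccc(OC)c(OC)c2)OC1`. It differs from compound 2 in one place: phenyl in place of 4-chlorobenzyl on an amide-type nitrogen. For the measured compounds named here, no measured step bears on this change, and the one step that exists is unreadable, so there is no basis for expecting a readable step in this assay in either direction. Compound 3 is estimated at 150000 nM, with a range from 40000 nM to 600000 nM, and the step from compound 2 to compound 3 is expected to be a step that the limit leaves unreadable from compound 2 to compound 3, most likely ending again at a limit.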

Compound 3, half-maximal inhibitory concentration: 45100 nM
Estimate against measurement, compound 3: 3.3-fold (0.52 log units) above; low and high end bracket the measured number.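

In this assay compound 3 gives 45100 nM, the only true number among the compounds shown, so a change on the amide nitrogen can bring this series inside the range the assay reports. The move from 4-chlorobenzyl to phenyl on that nitrogen is an at least 2.2-fold lower number from compound 2 to compound 3 (0.34 log units; beyond the scatter), and the move from propyl to phenyl is an at least 2.2-fold lower number from compound 1 to compound 3 (0.34 log units; beyond the scatter); each is a minimum size, as each starts from a compound that has only a limit of the assay. The step between the other two compounds cannot be read, and most of this small set still stays at the edge of what the assay can report: the limit of > 100000 nM in this assay, at which 2 of the 3 values shown sit.

The change from 4-chlorobenzyl to phenyl removes the chlorine and the carbon link to the ring at the same time, so the compounds shown cannot say which of the two matters. Going by these compounds, a plain benzyl group or a 4-chlorophenyl group on the same nitrogen would separate these two changes, and how much lower the number can go with other groups at this place also remains open.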